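Carbamoyl for Fluorophenoxy: Expected Solubility of Compound 4

The compounds below may be only part of what the source reports. "The series", "measured", "known", "first", "only" and "open" are said of these compounds alone.

Compound 3 `Cc1noc(-c2nc(C)c3c(c2N)C(=O)N(Cc2ccc(Oc4ccc(F)cc4)cc2)C3=O)n1` gives 23800 nM in a physicochemical assay for solubility, using the shake flask method, in simulated intestinal fluid, measured as kinetic solubility, with a stated time of 2 h, at 25 degrees C, at pH 6.5 (a higher number here means a more soluble compound, a lower number a less soluble compound), the lowest of the two numbers shown, with compound 2 `Cc1nc(C(=O)OC2CC2)c(N)c2c1C(=O)N(Cc1ccccc1)C2=O` nearest at 202000 nM. For compound 1 `CCOC(=O)c1nc(C)c2c(c1N)C(=O)N(Cc1ccccc1)C2=O` this assay reports only a limit, < 5000 nM. Among the measured compounds shown here, the single measured step, an at least 40-fold higher number from compound 1 to compound 2 (1.60 log units; beyond the scatter), concerns a different part of the shared core, cyclopropyl in place of ethyl on an oxygen next to a carbonyl group, and so bears only loosely on the present change. Compound 4 `Cc1noc(-c2nc(C)c3c(c2N)C(=O)N(Cc2ccc(C(N)=O)cc2)C3=O)n1` differs from compound 3 by carbamoyl in place of 4-fluorophenoxy on an aromatic carbon. For the measured compounds named here, no measured step touches this group, so the size of the expected step is uncertain. Compound 4 is expected to give 150000 nM, within a range from 40000 nM to 600000 nM. This means an expected step of a 6.3-fold higher number from compound 3 to compound 4 (0.80 log units; beyond the scatter) toward higher solubility.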

Compound 4, solubility: < 5000 nM
Compound 4: a limit, no number; the forecaster's own chance of this, stated with the estimate: 5%; middle value at least 30-fold (1.47 log units) from the limit.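

Among the compounds shown here, on this aromatic carbon, in this assay, carbamoyl in place of 4-fluorophenoxy gives an at least 4.7-fold lower number from compound 3 to compound 4 (0.67 log units; beyond the scatter), the first measured step at this position. Losing the six-membered aromatic ring and gaining a hydrogen-bond donor thus went with a lower number, not a higher one. Compound 4 reads as a limit and not a number, so this step has a floor but no known full size: the limit of < 5000 nM in this assay, at which 2 of the 4 values shown sit.

The compounds shown leave open whether the ring's loss or the carbamoyl's arrival accounts for the step. They also leave open how an amine or a carboxylic acid on this aromatic carbon would read in this assay.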